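The source may report more compounds than this note shows. Statements on the series, on what has been measured and on what is new or still open speak of the compounds shown alone.

Measured in a functional assay on PANC-1 cells (Homo sapiens) for inhibition, read by MTT assay, with a stated time of 24 h, tested at 10 uM; a lower number here means less inhibition, a higher number more inhibition at the concentration tested (going by the name of the read-out):

- compound 1 `COc1ccccc1NC(=O)Oc1cc(=O)n(CCCO)c2c1CC(CC=C(C)C)C(C)(C)C2` gives 71.1%
- compound 2 `CC(C)=CCC1Cc2c(OC(=O)Nc3ccc(F)cc3)cc(=O)n(CCCO)c2CC1(C)C` gives 71.2%
- compound 3 `CC(C)=CCC1Cc2c(OC(=O)Nc3ccc(F)c(F)c3)cc(=O)n(CCCO)c2CC1(C)C` gives 76.7%

The three numbers sit close together. Compound 3 tops the set on paper, but the step of a number 5.5 percentage points higher from compound 2 to compound 3 (within the scatter) and the step of a number 5.6 percentage points higher from compound 1 to compound 3 (within the scatter) both lie within the scatter, so the three compounds cannot be told apart by these numbers.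

Compound 4 `CC(C)=CCC1Cc2c(OC(=O)Nc3ccc(Cl)cc3)cc(=O)n(CCCO)c2CC1(C)C` differs from compound 3 in one place: 4-chlorophenyl in place of 3,4-difluorophenyl on an amide-type nitrogen. Within the data shown here, two measured steps bear on this kind of change at the phenyl group. Exchanging one phenyl group for another gave a number 0.1 percentage points higher from compound 1 to compound 2 (within the scatter), and adding a fluoro gave a number 5.5 percentage points higher from compound 2 to compound 3 (within the scatter). Neither move shifted the read-out beyond the scatter, and the change to a 4-chlorophenyl is of the same kind, so no shift beyond the scatter is expected: the expected step is a number 3.7 percentage points lower from compound 3 to compound 4 (within the scatter). Compound 4 is therefore estimated to give 73%, with a likely range from 62% to 84%.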

Compound 4, a percentage reported as inhibition, at one concentration (the size of the read-out at that concentration, not a potency): 49.8%
Estimate against measurement, compound 4: 23.2 percentage points above, outside the stated range (below it).
By their numbers in this assay, from the lowest: compound 4; then compounds 1, 2 and 3 (each within the scatter of the next).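

Swapping the group on the amide-type nitrogen can change the read-out in this assay: 4-chlorophenyl in place of 3,4-difluorophenyl gave a number 26.9 percentage points lower from compound 3 to compound 4 (beyond the scatter), the first step in this set beyond the scatter. Chloro in place of fluoro on an aromatic carbon gave a number 21.4 percentage points lower from compound 2 to compound 4 (beyond the scatter), so this one exchange on the phenyl ring is enough to lower the number. 4-chlorophenyl in place of 2-methoxyphenyl gave a number 21.3 percentage points lower from compound 1 to compound 4 (beyond the scatter), so the 2-methoxyphenyl, 4-fluorophenyl and 3,4-difluorophenyl groups stay level with one another while 4-chlorophenyl stands apart. Nothing measured here accounts for this drop.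

Going by these compounds, whether the drop is particular to chloro remains open. A 4-bromophenyl or 4-methylphenyl group on the same nitrogen would test that, and a 3-chlorophenyl group would show whether the place of the chloro on the ring counts.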